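The compounds below may be only part of what the source reports. "The series", "measured", "known", "first", "only" and "open" are said of these compounds alone.

Measured in an assay on isolated protein for inhibition of glutathione S-transferase Mu 2 (Homo sapiens), with a stated time of 10 min; on this read-out lower numbers stand for stronger inhibition and higher numbers for weaker inhibition:
compound 1, `O=C(CCC(=O)OCCCCCCSc1ccc([N+](=O)[O-])c2nonc12)Nc1ccccc1Cl`: 330 nM
compound 2, `O=C(CCC(=O)OCCCCCCSc1ccc([N+](=O)[O-])c2nonc12)Nc1cccc(Cl)c1`: 1100 nM

Among the measured compounds shown here, compound 2 holds the higher of the two numbers; the single measured step is a 3.3-fold higher number from compound 1 to compound 2 (0.52 log units; beyond the scatter), which only swaps one chlorophenyl for another on the amide-type nitrogen.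

Compound 3, `CCN(CC)CCCNC(=O)CCC(=O)OCCCCCCSc1ccc([N+](=O)[O-])c2nonc12`, differs from compound 2 by 3-(diethylamino)propyl in place of 3-chlorophenyl on an amide-type nitrogen. For the measured compounds named here, no measured step bears on trading the ring for this chain, so the direction is open. With nothing to go on beyond the two values, the step for compound 3 is estimated as a 1.4-fold higher number from compound 2 to compound 3 (0.13 log units; within the scatter), within the scatter. Compound 3 is therefore estimated at 1500 nM, with a wide range from 400 nM to 6000 nM.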

Compound 3, half-maximal inhibitory concentration: 440 nM
Estimate against measurement, compound 3: 3.4-fold (0.53 log units) above, within the range that was stated.
By their numbers in this assay, from the lowest: compounds 1 and 3 (each within the scatter of the next); then compound 2.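

In this assay, the amide-type nitrogen does not need an aromatic ring: 3-(diethylamino)propyl in place of 3-chlorophenyl gives a stronger result (a 2.5-fold lower number from compound 2 to compound 3 (0.40 log units; beyond the scatter)). Set against the 2-chlorophenyl amide, the same chain stays within the scatter (a 1.3-fold higher number from compound 1 to compound 3 (0.12 log units; within the scatter)), so a ring-free chain with an amine matches the better chlorophenyl isomer here. Nothing at hand accounts for this result.

On these data alone, whether the amine itself matters stays open. A plain hexyl chain on this nitrogen, or a chain ending in a dimethylamino group or a carboxylic acid, would separate the terminal amine from the chain alone.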